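Flipping Two Ring Stereocentres on a Peroxide Acid

The source may hold more compounds than are shown below. What is called first, only, known or untested is meant among the compounds shown, and "the series" means these compounds.

Compound 1 `C=C1CCCC(C)(C)C1CC[C@]1(C)CC[C@@H]([C@@H](C)C(=O)O)OO1` was tested in a functional assay on M14 cells (Homo sapiens) for inhibition; a lower number here means a stronger inhibitor of growth, a higher number a weaker inhibitor of growth. In that test compound 1 reaches only > 10000 nM, which is a limit of the assay and not a number. Compound 2 `C=C1CCCC(C)(C)C1CC[C@]1(C)CC[C@H]([C@@H](C)C(=O)OC)OO1` gives 6430 nM in this assay. Compound 3 `C=C1CCC[C@H]2[C@](C)(CC[C@]3(C)CC[C@@H]([C@@H](C)C(=O)O)OO3)[C@@H](C)CC[C@]12C` likewise returns only a limit, > 5000 nM. So compound 1 stands at the limit of > 10000 nM in this assay, at which 1 of the 3 values shown sits, and one further value sits at the limit of > 5000 nM in this assay, at which 1 of the 3 values shown sits. Compound 4 `C=C1CCCC(C)(C)C1CC[C@@]1(C)CC[C@H]([C@@H](C)C(=O)O)OO1` differs from compound 1 in this way: the two compounds have the same atoms and bonds; at least one stereo element is drawn with a configuration in one of them and without one in the other: 2 of 4 stereo elements differ; a stereocentre at a saturated ring carbon is drawn R in compound 1 and S in compound 4; a stereocentre at a saturated ring carbon is drawn S in compound 1 and R in compound 4. Among the measured compounds shown here, no step between measured compounds is known here, so the change is expected to bring no shift beyond the usual scatter in this assay. Compound 4 is therefore estimated at 9000 nM, with a range from 3000 nM to 30000 nM. The expected step of an at least 1.1-fold lower number from compound 1 to compound 4 (0.04 log units; that floor lies within the scatter) is accordingly small.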

Compound 4, concentration for 50% growth inhibition: 12200 nM
For compound 4 the middle estimate is 1.4-fold (0.13 log units) below the measured one; the range from low to high includes it.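

Compound 1 has only a limit of the assay and not a number, so the step from it to compound 4 cannot be read. From the compounds shown here alone, whether flipping the two ring stereocentres changes the result in this assay stays open.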